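The source may hold more compounds than are shown below. What is called first, only, known or untested is meant among the compounds shown, and "the series" means these compounds.

In a functional assay on LNCaP cells (Homo sapiens) for antiproliferative activity, read by WST assay, with a stated time of 3 days (a lower number here means a stronger inhibitor, a higher number a weaker inhibitor), compound 1 `CCCC(C)Oc1c(-c2cc(OC)c(OC)c(OC)c2)oc2ccccc2c1=O` gives 15100 nM, compound 2 `CCN(CC)CCCCCOc1c(-c2cc(OC)c(OC)c(OC)c2)oc2ccccc2c1=O` gives 10000 nM and compound 3 `CCCCCN(CCCCC)CCCOc1c(-c2cc(OC)c(OC)c(OC)c2)oc2ccccc2c1=O` gives 5100 nM. Compound 2 thus stands in the middle of these three numbers, within the scatter of each of the other two. Compound 4 `CCCCCN(CCCCC)CCCCCOc1c(-c2cc(OC)c(OC)c(OC)c2)oc2ccccc2c1=O` differs from it at one place: dipentylamino in place of diethylamino on a saturated chain carbon, five bonds along the chain from an oxygen on an aromatic ring. The closest measured evidence is a 2.0-fold lower number from compound 2 to compound 3 (0.29 log units; within the scatter), a step that also brings in dipentylamino, but in place of 2-(diethylamino)ethyl. The other measured step, a 1.5-fold lower number from compound 1 to compound 2 (0.18 log units; within the scatter), bears on it less directly. Neither lies beyond the scatter, so only a small move towards a lower number is expected in this assay. The expected change is a 1.8-fold lower number from compound 2 to compound 4 (0.26 log units; within the scatter). Compound 4 is estimated at 5500 nM, with an expected range of 2200 nM to 13000 nM.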

Compound 4, half-maximal inhibitory concentration: 7900 nM
For compound 4 the middle estimate is 1.4-fold (0.16 log units) below the measured one; the measured number falls inside the stated range.
By their numbers in this assay, from the lowest: compounds 3, 4, 2 and 1 (each within the scatter of the next, the first and the last beyond it).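

For the compounds shown here, the step of a 1.3-fold lower number from compound 2 to compound 4 (0.10 log units; within the scatter) in this assay is the first to isolate dipentylamino against diethylamino, on a saturated chain carbon, five bonds along the chain from an oxygen on an aromatic ring. Within the scatter, this exchange alone separates compound 2 and compound 4 by nothing that can be read as an effect. No measured evidence offers a reason for this result. The compounds shown leave open how a ring amine such as piperidine or morpholine would read at this place. On these data alone, a carboxylic acid in place of the amine also remains open.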